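Oxolanyl for isopropyl at the methoxy-bearing core of compound 2

The source may hold more compounds than are shown below. What is called first, only, known or untested is meant among the compounds shown, and "the series" means these compounds.

Compound 2 `COc1cc(-c2cnn3cc(OC)c(C(C)C)nc23)ccn1` gives 3800 nM in an assay on isolated protein for inhibition of activin receptor type-2A (Homo sapiens), read by 33P incorporation, with a stated time of 20 min, in the presence of a further agent that is not named here (on this read-out lower numbers stand for stronger inhibition and higher numbers for weaker inhibition), the highest of the three numbers recorded so far. Compound 1 `CNc1nc2c(-c3ccnc(OC)c3)cnn2cc1C` gives 1300 nM and compound 3 `CNc1nc2c(-c3ccnc(OC)c3)cnn2cc1C1CC1` gives 630 nM. Within the data shown here, the one single-point step among them, a 2.1-fold lower number from compound 1 to compound 3 (0.31 log units; beyond the scatter), puts a small ring where a chain stood. Compound 4 `COc1cc(-c2cnn3cc(OC)c(C4CCOC4)nc23)ccn1` differs from compound 2 by oxolan-3-yl in place of isopropyl on an aromatic carbon. Among the measured compounds shown here, no measured step replaces isopropyl with oxolan-3-yl on this core, so the step from compound 1 to compound 3 is only a loose guide. A small step in this assay is expected, in either direction, likely close to the scatter, so compound 4 is estimated at 3000 nM, between 1200 nM and 7500 nM, which corresponds to an expected 1.3-fold lower number from compound 2 to compound 4 (0.10 log units; within the scatter).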

Compound 4, half-maximal inhibitory concentration: 1900 nM
Compound 4: the middle estimate sits 1.6-fold (0.20 log units) above what was measured, and the stated range covers the measured number.
By their numbers in this assay, from the lowest: compound 3; then compounds 1, 4 and 2 (each within the scatter of the next, the first and the last beyond it).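

In this assay, oxolan-3-yl in place of isopropyl gives a 2.0-fold lower number from compound 2 to compound 4 (0.30 log units; within the scatter), so this aromatic carbon, ortho to a methoxy group, carries a saturated ring with a hydrogen-bond acceptor without a change beyond the scatter. The read-out therefore does not separate the branched chain from the oxygen-containing ring here. No measurement at hand accounts for this result. Still open, from the compounds shown here alone, is how a basic amine such as piperidin-4-yl or a carboxylic acid would read at this position. Also open, going by these compounds, is whether oxolan-3-yl reads the same on the core of compound 1.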